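A few compounds are considered here, and "the series" means these few. Any claim that something is new, unique, unknown or untested is made for them only; others in the source may bear on it.

Of the compounds shown here, three that share one core have been tested in a functional assay on HepG2 cells (Homo sapiens) for antiproliferative activity, read by MTT assay; a higher number here means a weaker inhibitor, a lower number a stronger inhibitor. Compound 1 `N#Cc1ncn(Cc2ccccc2Cl)c1/N=C/c1c[nH]c2ccccc12` gives 15000 nM. Compound 2 `N#Cc1ncn(Cc2ccccc2Cl)c1/N=C/c1ccc(O)cc1` gives 38200 nM. Compound 3 `N#Cc1ncn(Cc2ccccc2Cl)c1/N=C/c1ccc(Cl)cc1` gives 31000 nM. Compound 2 therefore carries the highest of the three numbers in this assay; its nearest neighbour is compound 3, and the gap between the two, a 1.2-fold lower number from compound 2 to compound 3 (0.09 log units; within the scatter), lies within the scatter, whereas the gap to compound 1 is wider and lies beyond the scatter.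

Compound 4 `COc1cc(/C=N/c2c(C#N)ncn2Cc2ccccc2Cl)ccc1O` has not yet been measured in this assay. It differs from compound 2 in one place: methoxy in place of hydrogen on an aromatic carbon. Going by the values given here, only one measured step touches the same part of the molecule, and it exchanges the hydroxy group for chloro rather than adding a new group: a 1.2-fold lower number from compound 2 to compound 3 (0.09 log units; within the scatter). Among the compounds with values here, that step was small, and nothing among the measured compounds shows what adding a methoxy group does, so there is no ground for expecting a shift in either direction beyond the scatter. The expected step is a 1.1-fold lower number from compound 2 to compound 4 (0.04 log units; within the scatter), that is, none beyond the scatter. Compound 4 is expected to give 35000 nM in this assay, with a range from 15000 nM to 85000 nM.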

Compound 4, half-maximal inhibitory concentration: > 40000 nM
Compound 4 was reported as a limit (the forecaster's own chance of this, stated with the estimate: 15%); middle value at least 1.1-fold (0.05 log units) away from the limit.
By their numbers in this assay, from the lowest: compound 1; then compounds 3 and 2 (each within the scatter of the next). At a limit, above all of these: compound 4.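

Placing a methoxy group on this aromatic carbon, ortho to a hydroxy group and meta to a large group, is the only change shown that adds a group to the ring instead of exchanging one, and in this assay it does not give a lower number: an at least 1.0-fold higher number from compound 2 to compound 4 (0.01 log units; that floor lies within the scatter). The value for compound 4 is a limit and not a number: the limit of > 40000 nM in this assay, at which 1 of the 4 values shown sits. The floor of the step therefore lies within the scatter, so the result rules out a clear gain from the methoxy group but cannot separate a change too small to matter from a large rise in the number.

The compounds shown leave open how far the true number of compound 4 lies from that of compound 2, and whether a methoxy group on this carbon would give the same outcome with the hydroxy group replaced by chloro. They also leave open whether a different group on this same carbon, such as an amine, a carboxylic acid or a longer chain like ethoxy, would give a lower number.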